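Ether aryl swap in a thiophene sulfonamide thiourea series

A few compounds are considered here, and "the series" means these few. Any claim that something is new, unique, unknown or untested is made for them only; others in the source may bear on it.

Compound 1 `O=S(=O)(NCCNC(=S)Nc1cccc(Cl)c1)c1ccc(-c2ccccc2OCc2ccccc2)s1` gives only a limit in a functional assay on HL-60 cells (Homo sapiens) for inhibition, read by CCK-8 assay, with a stated time of 48 h (a lower number here means a stronger inhibitor, a higher number a weaker inhibitor), namely > 50000 nM. Compound 3 `O=[N+]([O-])c1ccc(NC(=S)NCCNS(=O)(=O)c2ccc(-c3ccccc3OCc3ccccc3)s2)cc1` likewise sits at a limit in this assay, with > 50000 nM. Going by the values given here, compound 2 `Cc1cc(C)cc(NC(=O)NCCNS(=O)(=O)c2ccc(-c3ccccc3OCc3ccccc3)s2)c1` is the one numbered value, giving 2200 nM in this assay. The step of an at least 22-fold lower number from compound 1 to compound 2 (1.35 log units; beyond the scatter) and the step of an at least 22-fold higher number from compound 2 to compound 3 (1.35 log units; beyond the scatter) both concern the aryl group on the amine nitrogen, while the step that the two limits leave unreadable from compound 1 to compound 3 is unreadable because of the limit of > 50000 nM in this assay, at which 2 of the 3 values shown sit. Compound 4 `O=[N+]([O-])c1ccc(Oc2ccccc2-c2ccc(S(=O)(=O)NCCNC(=S)Nc3cccc(Cl)c3)s2)cc1` differs from compound 1 elsewhere: 4-nitrophenyl in place of benzyl on an oxygen on an aromatic ring. Among the compounds with values here, no measured step touches that oxygen, so the series gives no direction for this assay here. Compound 4 is therefore expected to stay near the limit, estimated at 50000 nM within 8000 nM to 200000 nM, which means a step of a number no higher from compound 1 to compound 4 (the limit leaves the size open).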

Compound 4, half-maximal inhibitory concentration: > 50000 nM
Compound 4: no number, only a limit; the forecaster's own chance of this, stated with the estimate: 70%; the middle value lies on the limit itself.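

No new step can be read between compound 1 and compound 4, as both values are limits: the limit of > 50000 nM in this assay, at which 3 of the 4 values shown sit.

The compounds shown leave open what 4-nitrophenyl in place of benzyl on the oxygen does in a compound with a numbered value, such as compound 2.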